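Long-chain amides: cytotoxicity notes on chain extension

The source may report more compounds than this note shows. Statements on the series, on what has been measured and on what is new or still open speak of the compounds shown alone.

compound 1 `CCCCCCCCCCCCCCCCCC(=O)N1CCOCC1`: 41.5 ug/mL
compound 2 `CCCCCCCCCCCCCCCC(=O)N1CCCC1`: 4.8 ug/mL
compound 3 `CCCCCCCCCCCCCCCC(=O)N1CCOCC1`: 28.9 ug/mL

In an ADME assay on HaCaT cells (Homo sapiens) for cytotoxicity, read by sulforhodamine B assay, with a stated time of 48 h (a higher number here means that more compound is tolerated, a lower number that less compound is tolerated), compound 2 gives the lowest of the three numbers. The nearest other value is reached by a 6.0-fold higher number from compound 2 to compound 3 (0.78 log units; beyond the scatter); compound 1 lies further off still. Compound 4 `CCCCCCCCCCCCCCCCCC(=O)N1CCCC1` is not yet measured. Its difference from compound 2 is ethyl in place of hydrogen on a saturated chain carbon, ten or more bonds along the chain from a carbonyl carbon. Going by the values given here, the single measured step that bears on this change runs the other way, a 1.4-fold lower number from compound 1 to compound 3 (0.16 log units; within the scatter), a shift within the scatter. No step beyond the scatter is therefore expected here: the estimated change is a 1.3-fold higher number from compound 2 to compound 4 (0.10 log units; within the scatter), if anything towards a higher number. Compound 4 is estimated at 6 ug/mL, with a range from 3 ug/mL to 12 ug/mL.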

Compound 4, concentration lethal to 50% of the cells: 6.3 ug/mL
Compound 4: the middle estimate sits 1.1-fold (0.02 log units) below what was measured; measured number inside the range.
By their numbers in this assay, from the lowest: compounds 2 and 4 (each within the scatter of the next); then compounds 3 and 1 (each within the scatter of the next).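

In this assay, ethyl in place of hydrogen on a saturated chain carbon, ten or more bonds along the chain from a carbonyl carbon, now stays within the scatter with pyrrolidin-1-yl on the carbonyl carbon too, with a 1.3-fold higher number from compound 2 to compound 4 (0.12 log units; within the scatter), so the chain extension reads alike on two cores: the same change on two cores in this assay, a 1.4-fold lower number (0.16 log units; within the scatter) from compound 1 to compound 3 and a 1.3-fold lower number (0.12 log units; within the scatter) from compound 4 to compound 2, 1.1-fold (0.04 log units) apart, within the scatter of two such steps

Pyrrolidin-1-yl in place of morpholin-4-yl also holds on the extended chain, with a 6.6-fold lower number from compound 1 to compound 4 (0.82 log units; beyond the scatter), matching the step on the shorter chain: the same change on two cores in this assay, a 6.0-fold higher number (0.78 log units; beyond the scatter) from compound 2 to compound 3 and a 6.6-fold higher number (0.82 log units; beyond the scatter) from compound 4 to compound 1, 1.1-fold (0.04 log units) apart, within the scatter of two such steps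

Open, from the compounds shown here alone, is whether a still longer chain or a much shorter one keeps this flat reading. Also open, going by these compounds, is how a piperidin-1-yl or diethylamino group on the carbonyl carbon compares.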